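The source may hold more compounds than are shown below. What is called first, only, known or untested is meant among the compounds shown, and "the series" means these compounds.

Compound 2 `O=C(Nc1ccc(NCC2CCNCC2)cc1Cl)c1cc(Cl)ccc1O` belongs to the same series as compound 1 `CCCC(C)(C)Nc1ccc(NC(=O)c2cc(Cl)ccc2O)c(Cl)c1`, whose tolerance in an ADME assay on A549 cells (Homo sapiens) for cytotoxicity, read by LDH release, with a stated time of 15 h (a higher number here means that more compound is tolerated, a lower number that less compound is tolerated), is recorded as 23700 nM. For the measured compounds named here, for compound 2 itself the entry in this assay reads "not determined" (no result reported); compound 2 stands without a number of its own, and there is no measured step from which the size of a change can be read.

Compound 3 `O=C(Nc1ccc(NCc2ccco2)cc1Cl)c1cc(Cl)ccc1O` differs from compound 2 in one place: furan-2-yl in place of piperidin-4-yl on a saturated chain carbon bound to a nitrogen on an aromatic ring. Going by the values given here, nothing was recorded for compound 2, and the expectation for compound 3 cannot be built on a step; it rests on the shared core of compound 1 and on the one change described. The author expects that a swap of this kind, at the position named, moves the half-maximal cytotoxic concentration in this assay by no more than the usual scatter, in either direction, with the value landing near that of compound 1.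

On that basis the estimated tolerance of compound 3 in this assay is 20000 nM, with a range from 6000 nM to 60000 nM.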

Compound 3, half-maximal cytotoxic concentration: 76300 nM
The estimate for compound 3 lay 3.8-fold (0.58 log units) below the measured number, and the stated range ends below it.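

In this assay, for the compounds shown here, putting (furan-2-yl)methyl in place of 1,1-dimethylbutyl on a nitrogen on an aromatic ring gives a 3.2-fold higher number from compound 1 to compound 3 (0.51 log units; beyond the scatter) and is the first measured step. It shows that the group on this nitrogen is not silent in this assay, since this one change, with the rest of the shared core kept, moves the half-maximal cytotoxic concentration beyond the usual scatter, towards more compound tolerated; the step from compound 2 to compound 3 cannot be read, as compound 2 has no number. Nothing available explains the size of this step.

With only this one pair, the compounds shown leave open whether the higher number goes with the furan-2-yl ring itself or would also appear with a (thiophen-2-yl)methyl or benzyl group on the same nitrogen. They also leave open where an unbranched chain such as n-butyl, or a simple methyl group, would fall on this nitrogen relative to the 1,1-dimethylbutyl of compound 1 and the (furan-2-yl)methyl of compound 3.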